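Working notes: from compound 2 to compound 3

The compounds below may be only part of what the source reports. "The series", "measured", "known", "first", "only" and "open" are said of these compounds alone.

Measured in an ADME assay on microsomes from liver (Mus musculus) for metabolic stability, with a stated time of 10 min (on this read-out higher numbers stand for a more stable compound and lower numbers for a less stable compound), so far:
compound 1 `O=C(O)C12CCC(C(=O)N3CC[C@](c4ccc(C(F)(C(F)(F)F)C(F)(F)F)cc4)(S(=O)(=O)c4ccc(F)cc4)C3)(CC1)OC2` gives 94% remaining
compound 2 `O=C([C@H]1CC[C@H](CO)CC1)N1CC[C@](c2ccc(C(F)(C(F)(F)F)C(F)(F)F)cc2)(S(=O)(=O)c2ccc(F)cc2)C1` gives 63% remaining

Compound 2 is the lower of the two. Compound 3 `CCC1(C(=O)N2CC[C@](c3ccc(C(F)(C(F)(F)F)C(F)(F)F)cc3)(S(=O)(=O)c3ccc(F)cc3)C2)CCS(=O)(=O)CC1` differs from it by 4-ethyl-1,1-dioxothian-4-yl in place of 4-(hydroxymethyl)cyclohexyl on a carbonyl carbon on a carbonyl carbon. Within the data shown here, one measured step bears on this, a large one at the same carbonyl carbon: a number 31 percentage points lower from compound 1 to compound 2 (beyond the scatter) in this assay but with a different group. A single step shows no rule, yet with compound 2 at 63% there is more room upward, so a moderate rise is expected. The expected change is a number 17 percentage points higher from compound 2 to compound 3 (beyond the scatter) on this estimate. Compound 3 is estimated at 80% (60% to 95%).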

Compound 3, percent of the compound remaining: 0%
Beside the measured number, compound 3's estimate is 80 percentage points above it, outside the stated range (below it).
By their numbers in this assay, from the lowest: compound 3; then compound 2; then compound 1.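

In this assay the place on a carbonyl carbon proves more sensitive than the first pair showed: 4-ethyl-1,1-dioxothian-4-yl in place of 4-(hydroxymethyl)cyclohexyl gives a number 63 percentage points lower from compound 2 to compound 3 (beyond the scatter), and the same group in place of that of compound 1 gives a number 94 percentage points lower from compound 1 to compound 3 (beyond the scatter), so the shared core alone does not secure stability. Nothing at hand accounts for this loss. The ethyl and the 1,1-dioxo part enter together, so the step cannot be assigned to either. On these data alone, how a group bearing an amine on the carbonyl carbon would read also remains open.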